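Benzyl ester to free acid on the glutamine side chain

The compounds below may be only part of what the source reports. "The series", "measured", "known", "first", "only" and "open" are said of these compounds alone.

Two compounds of this series have numbers in a functional assay on the whole organism (Tail, strain ICR) with Mus musculus as the target, in the tail flick test, with a stated time of 150 min, at a dose of 25 umol/kg by the oral route (on this read-out lower numbers stand for a weaker effect and higher numbers for a stronger effect at the one dose given), so far. Compound 2 `NC(=O)CC[C@H](NC(=O)CN(c1nc(Cl)nc2[nH]cnc12)C1CC1)C(=O)OCc1ccccc1` stands highest of the two: in this assay compound 2 gives 31.1%. Compound 1 `CC(C)[C@H](NC(=O)CN(c1nc(Cl)nc2[nH]cnc12)C1CC1)C(=O)O` carries a different amino acid and a free carboxy group; in this assay compound 1 gives 7.86%, a number that lies beyond the scatter below that of compound 2. The two compounds differ in more than one place, so their values show only that the one with the free carboxy group sits low.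

Compound 3 `NC(=O)CC[C@H](NC(=O)CN(c1nc(Cl)nc2[nH]cnc12)C1CC1)C(=O)O` is the next member to be measured. It keeps the glutamine side chain of compound 2 and differs from it in one place: hydrogen in place of benzyl on an oxygen next to a carbonyl group

For the measured compounds named here, no step between measured compounds with this single change is available. The expectation rests on compound 1, which also carries a carboxy group and gives 7.86%. On that basis a downward step a number 19.1 percentage points lower from compound 2 to compound 3 (beyond the scatter) is expected, beyond the scatter. For compound 3 in this assay the estimate is 12%, with a range from 0% to 30%.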

Compound 3, a percentage reported as activity, at one dose (the size of the read-out at that dose, not a potency): 11.4%
The estimate for compound 3 lay 0.6 percentage points above the measured number; the range from low to high includes it.
By their numbers in this assay, from the lowest: compounds 1 and 3 (each within the scatter of the next); then compound 2.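

In this assay, for the compounds shown here, hydrogen in place of benzyl on an oxygen next to a carbonyl group comes with a number 19.7 percentage points lower from compound 2 to compound 3 (beyond the scatter) and gives the first reading of this change with the glutamine side chain held constant, so the low number of the free acid no longer rests on a comparison that also changes the side chain. With the carboxy group kept, 2-carbamoylethyl in place of isopropyl on a saturated chain carbon bound to an amide-type nitrogen and a carbonyl carbon comes with a number 3.5 percentage points higher from compound 1 to compound 3 (within the scatter) and leaves the two free acids undistinguished in this assay, so at this dose the benzyl ester separates from the acids while this side-chain change does not. Nothing measured here bears on why the benzyl ester and the free acid read differently.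

As far as these compounds go, whether the benzyl step is specific to the glutamine side chain remains open, since the isopropyl compound appears only as the free acid. Also open, from the compounds shown here alone, is how a methyl ester, an ethyl ester or a primary amide in place of the carboxy group would read, and therefore whether the benzyl ring or the capping of the carboxy group goes with the higher number.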